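A few compounds are considered here, and "the series" means these few. Any claim that something is new, unique, unknown or untested is made for them only; others in the source may bear on it.

Measured so far in a functional assay on HeLa cells (Homo sapiens) for antiproliferative activity, read by sulforhodamine B assay, with a stated time of 72 h; on this read-out higher numbers stand for weaker inhibition and lower numbers for stronger inhibition:

- Compound 1 `Cc1cc(C)nc(NS(=O)(=O)c2ccc(Nc3nncc4ccccc34)cc2)n1`: 3.5 nM
- Compound 2 `O=S(=O)(Nc1ccccn1)c1ccc(Nc2nncc3ccccc23)cc1`: 26 nM

Compound 2 has the higher of these two numbers, so it is the weaker inhibitor of the pair. The next compound, compound 3 `Cc1cc(NS(=O)(=O)c2ccc(Nc3nncc4ccccc34)cc2)no1`, keeps the core of compound 2 and changes only the group on the sulfonamide nitrogen: 5-methyl-1,2-oxazol-3-yl in place of pyridin-2-yl on a sulfonamide nitrogen. In words, this places 5-methyl-1,2-oxazol-3-yl in place of pyridin-2-yl on a sulfonamide nitrogen.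

Within the data shown here, one measured step bears on this change, made at the same place: a 7.4-fold higher number from compound 1 to compound 2 (0.87 log units; beyond the scatter). It shows that swapping this group can shift the number by a modest amount. A single step gives no rule for the new group, so the direction remains uncertain. Among the measured compounds shown here, the only other group measured there, in compound 1 at 3.5 nM, gives a lower number than pyridin-2-yl does, so a modest move downward, smaller than the measured step, is expected. The estimated change is a 2.2-fold lower number from compound 2 to compound 3 (0.34 log units; beyond the scatter). For compound 3 the expected value is 12 nM, with an estimated range of 3 nM to 50 nM.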

Compound 3, half-maximal inhibitory concentration: 13 nM
Compound 3: the middle estimate sits 1.1-fold (0.03 log units) below what was measured, within the range that was stated.
By their numbers in this assay, from the lowest: compound 1; then compounds 3 and 2 (each within the scatter of the next).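

Swapping pyridin-2-yl for 5-methyl-1,2-oxazol-3-yl on the sulfonamide nitrogen gives a 2.0-fold lower number from compound 2 to compound 3 (0.30 log units; within the scatter), so in this assay a five-membered aromatic ring with 2 hetero atoms can stand in for a six-membered aromatic ring with 1 hetero atom without a change that can be told from the scatter. The earlier pair showed only that this position can respond to a change of group, whereas this result shows that two different rings can give numbers that cannot be told apart. Compound 1 also stays clear of the new compound, with a 3.7-fold higher number from compound 1 to compound 3 (0.57 log units; beyond the scatter), so its 4,6-dimethylpyrimidin-2-yl group gives the strongest inhibition of the three, but no measurement here explains this order.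

From the compounds shown here alone, all three compounds carry an aromatic ring on the sulfonamide nitrogen, so it remains open how a plain hydrogen or an open chain such as ethyl would behave there. It is also unclear how much of the edge of compound 1 lies in its two methyl groups and how much in the ring itself, which an unsubstituted pyrimidin-2-yl group would help to separate.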